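Oxadiazoline cinnamides: dichlorophenyl variant of compound 3

The source may report more compounds than this note shows. Statements on the series, on what has been measured and on what is new or still open speak of the compounds shown alone.

Measured so far:
Compound 1 `O=C(/C=C\c1cccc(O)c1)N1N=C(c2ccncc2)OC1c1c[nH]c2ccccc12`. In an ADME assay on PANC-1 cells (Homo sapiens) for cytotoxicity, read by MTT assay, with a stated time of 48 h (a lower number here means a stronger inhibitor of growth, a higher number a weaker inhibitor of growth), compound 1 gives > 30 ug/mL, a limit of the assay.
Compound 2 `O=C(/C=C\c1ccccc1[N+](=O)[O-])N1N=C(c2ccncc2)OC1c1c[nH]c2ccccc12`. In this assay compound 2 gives > 30 ug/mL, a limit of the assay.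
Compound 3 `O=C(/C=C\c1cccc(Cl)c1)N1N=C(c2ccncc2)OC1c1c[nH]c2ccccc12`. In this assay compound 3 gives > 30 ug/mL, a limit of the assay.

Compound 3 therefore stands only at the limit of > 30 ug/mL in this assay, at which 3 of the 3 values shown sit, with no number of its own. The steps a step that the two limits leave unreadable from compound 1 to compound 3 and a step that the two limits leave unreadable from compound 2 to compound 3 are unreadable, as is a step that the two limits leave unreadable from compound 1 to compound 2; the substituent on the double-bonded chain carbon has so far produced no readable value at all.

Compound 4 `O=C(/C=C\c1ccc(Cl)cc1Cl)N1N=C(c2ccncc2)OC1c1c[nH]c2ccccc12` differs from compound 3 by 2,4-dichlorophenyl in place of 3-chlorophenyl on a double-bonded chain carbon bound to a double-bonded chain carbon. Going by the values given here, no measured step bears on this change with a readable size, so no direction beyond the scatter is expected. Compound 4 is expected most likely to return another limit; the estimate for compound 4 in this assay is 40 ug/mL, range 18 ug/mL to 100 ug/mL. The expected step that the limit leaves unreadable from compound 3 to compound 4 is accordingly close to none.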

Compound 4, concentration for 50% growth inhibition: > 30 ug/mL
Compound 4: no number, only a limit (the forecaster's own chance of this, stated with the estimate: 70%); the middle value does not contradict the limit.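

In this assay compound 4 gives > 30 ug/mL, a limit of the assay. Its steps from compound 1, compound 2 and compound 3 cannot be read: the limit of > 30 ug/mL in this assay, at which 4 of the 4 values shown sit. Going by these compounds, whether any group on this double-bonded chain carbon gives a readable value in this assay remains open.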